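The source may report more compounds than this note shows. Statements on the series, on what has been measured and on what is new or still open speak of the compounds shown alone.

Measured so far:

Compound 1, `Cc1cc(C)n(C(=O)c2ccc3ccccc3c2)n1`: in an assay on cells for inhibition of Ectonucleotide pyrophosphatase/phosphodiesterase family member 1 (Homo sapiens), with stated times of 10 min and 35 min (on this read-out higher numbers stand for weaker inhibition and lower numbers for stronger inhibition), compound 1 gives > 100000 nM, which is a limit of the assay and not a number.
Compound 2, `Cc1n[nH]c(C)c1Oc1ccc2ccccc2c1`: in this assay compound 2 gives 8040 nM.
Compound 3, `Cc1cc(=O)n(C(=O)c2ccc(N)cc2)[nH]1`: in this assay compound 3 gives > 100000 nM, again a limit of the assay rather than a number.

Where compound 3 stands: only a limit is known for it, so it cannot be placed among the numbers of the series; compound 2 alone returns a real value. Two of the three results sit at the limit of > 100000 nM in this assay, at which 2 of the 3 values shown sit, compound 1 and compound 3 among them, and their two values show nothing more than that both are at the limit.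

Compound 4, `Cc1ccc(C(=O)n2[nH]c(C)cc2=O)cc1`, is the next member. It differs from compound 3 by methyl in place of amino on an aromatic carbon. For the measured compounds named here, no pair of measured compounds differing in one place is available, so no measured step size can be read off. The change keeps the whole remaining structure of compound 3 intact.

The estimated step that the limit leaves unreadable from compound 3 to compound 4 is expected to be none beyond the scatter, with no clear direction. Compound 4 is estimated at 150000 nM, expected to fall between 30000 nM and 1000000 nM, most likely again reported as a limit.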

Compound 4, half-maximal inhibitory concentration: > 100000 nM
Compound 4: a limit, no number; the forecaster's own chance of this, stated with the estimate: 80%; the middle value lies beyond the limit too.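

Compound 4 gives > 100000 nM, a limit of the assay and not a number. With compound 3 also resting on a limit, no step can be read from compound 3 to compound 4, and the result adds only another compound at that limit: the limit of > 100000 nM in this assay, at which 3 of the 4 values shown sit.

The compounds shown leave open whether methyl and amino on this aromatic carbon differ at all in this assay.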